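A few compounds are considered here, and "the series" means these few. Any claim that something is new, unique, unknown or untested is made for them only; others in the source may bear on it.

Working notes on the amide series in an ADME assay on L02 cells (Homo sapiens) for antiproliferative activity, read by MTT assay, with a stated time of 48 h; on this read-out higher numbers stand for weaker inhibition and lower numbers for stronger inhibition. Compound 1 `CCn1c(C(=O)NCCCN(C)C)ccc1C(CC)(CC)c1ccc(OCCC(O)(CC)CC)c(C)c1` gives 2420 nM. Compound 2 `CCOc1ccc(NC(=O)c2ccc(C(CC)(CC)c3ccc(OCCC(O)(CC)CC)c(C)c3)n2CC)cc1` reads > 50000 nM, which is a limit of the assay and not a number. Compound 3 `CCC(C)C(NC(=O)c1ccc(C(CC)(CC)c2ccc(OCCC(O)(CC)CC)c(C)c2)n1CC)C(=O)O` gives 9990 nM, the higher of the two true numbers, with compound 1 as its nearest neighbour.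

Compound 4 `CCn1c(C(=O)N(C)CC(=O)O)ccc1C(CC)(CC)c1ccc(OCCC(O)(CC)CC)c(C)c1` has not yet been measured. Its difference from compound 3 is (carboxymethyl)(methyl)amino in place of (1-carboxy-2-methylbutyl)amino on a carbonyl carbon.

Three measured steps change the group on this same amide-type nitrogen: an at least 20-fold higher number from compound 1 to compound 2 (1.31 log units; beyond the scatter), a 4.1-fold higher number from compound 1 to compound 3 (0.62 log units; beyond the scatter) and an at least 5.0-fold lower number from compound 2 to compound 3 (0.69 log units; beyond the scatter). The two steps involving compound 2 rest on its limit. Within the data shown here, none of the three exchanges one carboxy-bearing group for another, so no measured step carries this change directly. Compound 3 and compound 4 both keep a carboxy group, so a move like an at least 20-fold higher number from compound 1 to compound 2 (1.31 log units; beyond the scatter) is not expected. In this assay, the expected result is no step beyond the scatter, with a slight lean towards a higher number. The estimated change is a 1.6-fold higher number from compound 3 to compound 4 (0.20 log units; within the scatter). For compound 4 the estimated value is 16000 nM, with an expected range of 6000 nM to 45000 nM.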

Compound 4, half-maximal inhibitory concentration: 2150 nM
Beside the measured number, compound 4's estimate is 7.4-fold (0.87 log units) above it; measured number outside the range, below it.
By their numbers in this assay, from the lowest: compounds 4 and 1 (each within the scatter of the next); then compound 3. At a limit, above all of these: compound 2.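

In this assay, a 4.6-fold lower number from compound 3 to compound 4 (0.67 log units; beyond the scatter), so keeping a carboxy group on this amide does not by itself fix the number: the exchange of (1-carboxy-2-methylbutyl)amino for (carboxymethyl)(methyl)amino on a carbonyl carbon is a real step. Against the dimethylamino-bearing amide, a 1.1-fold lower number from compound 1 to compound 4 (0.05 log units; within the scatter), which means that among the compounds shown, (3-(dimethylamino)propyl)amino and (carboxymethyl)(methyl)amino cannot be told apart here, while (1-carboxy-2-methylbutyl)amino, the other carboxy-bearing group, stands apart from both. The step of an at least 23-fold lower number from compound 2 to compound 4 (1.36 log units; beyond the scatter) extends the spread at this position, but compound 2 reads as a limit, so the size of that step is only a bound: the limit of > 50000 nM in this assay, at which 1 of the 4 values shown sits.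

The change from compound 3 to compound 4 shortens the carboxy-bearing chain and also replaces the amide hydrogen with methyl, and the compounds shown do not separate these two parts. A (carboxymethyl)amino group, or a (1-carboxy-2-methylbutyl)(methyl)amino group, would each leave only one of the two parts in play and would show which of them goes with the lower number.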